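The compounds below may be only part of what the source reports. "The series", "measured", "known", "first", "only" and "open" are said of these compounds alone.

In a functional assay on WiDr cells (Homo sapiens) for antiproliferative activity, read by sulforhodamine B assay, with a stated time of 48 h (a higher number here means a weaker inhibitor of growth, a lower number a stronger inhibitor of growth), compound 1 `CC(C)(C)[Si](C)(C)O[C@@H]1CCCO[C@@H]1CO` gives > 100000 nM, which is a limit of the assay and not a number. Compound 2 `CC(C)(C)[Si](C)(C)O[C@@H]1CCCO[C@@H]1COCC(=O)O` gives > 100000 nM, which is also a limit. All the evidence so far therefore rests on (the limit of > 100000 nM in this assay, at which 2 of the 2 values shown sit), and compound 2 has no exact value of its own.

Compound 3 `C=CCOC[C@H]1OCCC[C@H]1O[Si](C)(C)C(C)(C)C` keeps the shared core and alters only the end of the side chain: vinyl in place of carboxy on a saturated chain carbon bound to an oxygen on a saturated carbon. Vinyl takes the place of carboxy on a saturated chain carbon bound to an oxygen on a saturated carbon, so carboxymethyl becomes allyl.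

Among the measured compounds shown here, the one measured step that bears on this change is a step that the two limits leave unreadable from compound 1 to compound 2, the step that carries the carboxymethyl group. Its size cannot be read, so it offers no measured guide to how much replacing that group might matter. The expectation in this assay is therefore for no clear change, and another limit is the likeliest report.

Compound 3 is expected near 90000 nM, within an estimated range of 30000 nM to 100000 nM. This estimate implies an expected at least 1.1-fold lower number from compound 2 to compound 3 (0.04 log units; that floor lies within the scatter).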

Compound 3, concentration for 50% growth inhibition: 88000 nM
Beside the measured number, compound 3's estimate is 1.0-fold (0.01 log units) above it; low and high end bracket the measured number.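

In this assay, among the compounds shown here, compound 3 is the first of the three compounds to give an exact number rather than a limit, so this side chain now has one firm reference point. Vinyl in place of carboxy gives an at least 1.1-fold lower number from compound 2 to compound 3 (0.05 log units; that floor lies within the scatter), and allyl in place of hydrogen on the oxygen gives an at least 1.1-fold lower number from compound 1 to compound 3 (0.05 log units; that floor lies within the scatter). Neither step establishes a real gain in growth inhibition, and their true sizes stay hidden because the comparison partners sit at a limit of the assay: the limit of > 100000 nM in this assay, at which 2 of the 3 values shown sit.

The compounds shown leave open whether either step truly exceeds the scatter, as neither compound 1 nor compound 2 has an exact value. They also leave open how an amine or a longer chain in place of the allyl group would compare with compound 3.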